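The source may hold more compounds than are shown below. What is called first, only, known or untested is meant among the compounds shown, and "the series" means these compounds.

In a functional assay on MONO-MAC-6 cells (Homo sapiens) for inhibition (on this read-out higher numbers stand for weaker inhibition and lower numbers for stronger inhibition), compound 1 `O=C(NO)[C@H]1CCCCN1S(=O)(=O)N1CC=C(c2ccc(Cl)cc2)CC1` gives 430 nM; 480 nM (2 entries), and the several entries of compound 1 in this assay, 430 nM; 480 nM (2 entries) shows how closely repeated runs of this kind agree. Compound 2 `COc1cccc(C2=CCN(S(=O)(=O)N3CCCC[C@@H]3C(=O)NO)CC2)c1` gives 260 nM, and compound 3 `O=C(NO)[C@H]1CCCCN1S(=O)(=O)N1CC=C(c2cccc(-c3ccccc3)c2)CC1` gives 7600 nM. Compound 2 therefore holds the lowest single number among the compounds with one value; its nearest neighbour is compound 3, and the step of a 29-fold higher number from compound 2 to compound 3 (1.47 log units; beyond the scatter) is large and well beyond the scatter. Compound 1, with its two entries, sits between the two.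

Compound 4 `CCCc1ccc(C2=CCN(S(=O)(=O)N3CCCC[C@@H]3C(=O)NO)CC2)cc1` is not yet measured in this assay. It differs from compound 2 in one place: 4-propylphenyl in place of 3-methoxyphenyl on a double-bonded ring carbon. The group that leaves is the same 3-methoxyphenyl that compound 3 also loses, and in that case the entering phenyl made the number markedly higher. Compound 4 instead brings in 4-propylphenyl, a group of similar size to the phenyl but with no aromatic ring added and no hydrogen-bond acceptor kept. Among the compounds with values here, the only measured step that bears on the change points upward, so a weaker inhibition than compound 2 is expected for compound 4, though not necessarily as large a loss as compound 3 showed. The step of a 5.8-fold higher number from compound 2 to compound 4 (0.76 log units; beyond the scatter) is the expected size of that change. Compound 4 is estimated at 1500 nM, within a range from 400 nM to 6000 nM.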

Compound 4, half-maximal inhibitory concentration: 2600 nM
Estimate against measurement, compound 4: 1.7-fold (0.24 log units) below, and the stated range covers the measured number.
By their numbers in this assay, from the lowest: compound 2; then compound 4; then compound 3.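

In this assay, this position on the double-bonded ring carbon now has a second replacement for 3-methoxyphenyl, and it also weakens inhibition, with a 10-fold higher number from compound 2 to compound 4 (1.00 log units; beyond the scatter). Within the data shown here, until now, the only evidence for a loss here was a 29-fold higher number from compound 2 to compound 3 (1.47 log units; beyond the scatter), so the loss could have belonged to that one replacement, whereas two different groups now point the same way, although 3-methoxyphenyl remains the best of the three groups in this single series. The new step is also far wider than the spread between repeated runs, so it is not an artefact of assay noise: the several entries of compound 1 in this assay, 430 nM; 480 nM (2 entries)

As far as these compounds go, what remains open is which part of the change matters, since the step from 3-methoxyphenyl to 4-propylphenyl removes the methoxy group, adds a propyl chain and moves the substituent to a different ring position all at once. A 4-methoxyphenyl or 3-propylphenyl group would separate these effects, and an aromatic ring carrying an amine or a carboxylic acid would test whether this position accepts anything beyond the neutral groups shown here.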